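Swapping One Aryl Group: From Compound 2 to Compound 3

The source may hold more compounds than are shown below. What is called first, only, known or untested is meant among the compounds shown, and "the series" means these compounds.

Two compounds share a common core and differ in the groups attached to it. Compound 1 `Cc1c(-c2cc(Cl)cc(Cl)c2)c(C(=O)O)nn1-c1nc(-c2cccnc2)c(SC(C)C)s1` is recorded as "not active" (no number reported) in a functional assay on BJAB cells (Homo sapiens) for antiproliferative activity, with a stated time of 4 days (a lower number here means that less compound is needed, a higher number that more compound is needed for the effect), with no number given. Among the compounds with values here, compound 2 `Cc1cc(C)cc(-c2c(C)nn(-c3nc(-c4ccc(Cl)c(Cl)c4)c(SC(C)C)s3)c2C(=O)O)c1` gives 2700 nM in this assay; it is the only compound with a numerical result, so it stands alone as the reference point. Compound 3 `Cc1nn(-c2nc(-c3ccc(Cl)c(Cl)c3)c(SC(C)C)s2)c(C(=O)O)c1-c1ccc(Cl)cc1` has not been measured. It differs from compound 2 in one place: 4-chlorophenyl in place of 3,5-dimethylphenyl on an aromatic carbon. Within the data shown here, no measured pair shows the effect of such a change, so the size of the step from compound 2 to compound 3 cannot be read from the data. The expectation is a modest change, most likely a small loss, with the step of a 1.5-fold higher number from compound 2 to compound 3 (0.17 log units; within the scatter) staying close to the scatter of repeated measurements. Compound 3 is therefore estimated at 4000 nM, with a plausible range from 1500 nM to 12000 nM.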

Compound 3, half-maximal effective concentration: 2500 nM
The estimate for compound 3 lay 1.6-fold (0.20 log units) above the measured number; the range from low to high includes it.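

In this assay, the step at this position is a 1.1-fold lower number from compound 2 to compound 3 (0.03 log units; within the scatter), so 4-chlorophenyl and 3,5-dimethylphenyl cannot be told apart here. This is the only pair shown that differs in one place, and it gives the first direct reading of this position: with the rest of the molecule unchanged, one of these rings can take the place of the other without a change that stands out from the scatter. Nothing measured here offers a reason why the two groups read alike.

On these data alone, it remains open whether this position stays as undemanding for rings of a different kind, such as a phenyl ring carrying an amine or a carboxylic acid. It is also unknown how a longer chain in place of the ring would read.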